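The source may report more compounds than this note shows. Statements on the series, on what has been measured and on what is new or still open speak of the compounds shown alone.

Of the compounds shown here, two sharing one core have been measured so far. Compound 1 `CC(C)CCc1c(OCCCCCC(=O)NO)ccc(CCC(=O)NO)c1O` gives 2520 nM in a functional assay on PC-3 cells (Homo sapiens) for antiproliferative activity, read by sulforhodamine B assay, with a stated time of 48 h; a lower number here means a stronger inhibitor of growth, a higher number a weaker inhibitor of growth. Compound 2 `CC(C)CCc1c(OCCCCCC(=O)NO)ccc2ccc(=O)oc12` gives 740 nM in this assay, the lower of the two numbers and far enough from compound 1 to lie beyond the scatter, so compound 2 is the stronger of the pair. Compound 3 `CC(C)CCc1c(OCCCCC(=O)NO)ccc2ccc(=O)oc12` is not yet measured; it differs from compound 2 in one place: hydroxycarbamoyl in place of (hydroxycarbamoyl)methyl on a saturated chain carbon, four bonds along the chain from an oxygen on an aromatic ring. Among the compounds with values here, no measured step of this kind is on hand. A modest weakening is expected for compound 3, a step of a 1.5-fold higher number from compound 2 to compound 3 (0.17 log units; within the scatter) that may still sit within the scatter. Compound 3 is estimated at 1100 nM, with a range from 400 nM to 3000 nM.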

Compound 3, concentration for 50% growth inhibition: 1940 nM
For compound 3 the middle estimate is 1.8-fold (0.25 log units) below the measured one; measured number inside the range.
By their numbers in this assay, from the lowest: compound 2; then compounds 3 and 1 (each within the scatter of the next).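

Swapping (hydroxycarbamoyl)methyl for hydroxycarbamoyl at this saturated chain carbon shortens the chain and gives a 2.6-fold higher number from compound 2 to compound 3 (0.42 log units; beyond the scatter) in this assay as the first one-place step. It shows that growth inhibition in these cells responds to the length of this chain, with the shorter chain giving the weaker inhibitor of this pair. No measurement on hand explains this loss.
Still open, on these data alone, is whether a longer chain would strengthen or weaken growth inhibition. As far as these compounds go, it is also open whether a carboxylic acid or an amine could stand in place of the hydroxycarbamoyl end group.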